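Swapping the Sulfamoyl Group on a Shared Core

The source may report more compounds than this note shows. Statements on the series, on what has been measured and on what is new or still open speak of the compounds shown alone.

Compound 1 `CCCN(CCC)S(=O)(=O)c1ccc(S(=O)(=O)N2CCC[C@@H](C(=O)OCC)C2)cc1` is the stronger of the two compounds measured in a functional assay on BXPC-3 cells (Homo sapiens) for inhibition, read by MTT assay, with a stated time of 7 days (a higher number here means a weaker inhibitor, a lower number a stronger inhibitor), where compound 1 gives 2500 nM. Compound 2 `CCN(CC)S(=O)(=O)c1ccc(S(=O)(=O)N2CCC[C@@H](C(=O)NC3COC3)C2)cc1` gives 13800 nM, a gap beyond the usual scatter; compound 2 differs from compound 1 at two places at once, so its number alone says nothing about either change. Compound 3 `CCOC(=O)[C@@H]1CCCN(S(=O)(=O)c2ccc(S(=N)(=O)N(CC)CC)cc2)C1` has not yet been measured. It differs from compound 1 as follows: a group of 8 heavy atoms (4 carbon, 2 nitrogen, 1 oxygen, 1 sulfur; no ring) in place of a group of 10 heavy atoms (6 carbon, 1 nitrogen, 2 oxygen, 1 sulfur; no ring), on an aromatic carbon. Among the compounds with values here, no measured pair isolates this change, so there is no direct guide to its effect, and the two known numbers only show that moving away from compound 1 has so far meant weaker inhibition. A modest weakening is expected, a step of a 1.8-fold higher number from compound 1 to compound 3 (0.26 log units; within the scatter). In this assay compound 3 is therefore estimated at 4500 nM, with a likely range from 1500 nM to 14000 nM.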

Compound 3, half-maximal inhibitory concentration: 3600 nM
Beside the measured number, compound 3's estimate is 1.3-fold (0.10 log units) above it; low and high end bracket the measured number.
By their numbers in this assay, from the lowest: compounds 1 and 3 (each within the scatter of the next); then compound 2.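

Within the data shown here, this is the first step on the shared core that changes one place alone. On an aromatic carbon para to a large group, dipropylsulfamoyl gives way to a group with fewer heavy atoms and a hydrogen-bond donor, and this assay shows a 1.4-fold higher number from compound 1 to compound 3 (0.16 log units; within the scatter) and so cannot tell the two compounds apart. This position therefore accepts the swap with no loss that can be read in this assay, but no measurement shown here explains that outcome.

From the compounds shown here alone, the step alters the alkyl chains and the group around the sulfur together, so the share of each stays open, and a compound with diethylsulfamoyl on the same ethyl ester core would separate them. Going by these compounds, how a simple amine or a carboxylic acid would fare at this aromatic carbon also remains unknown.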